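A few compounds are considered here, and "the series" means these few. Any claim that something is new, unique, unknown or untested is made for them only; others in the source may bear on it.

Compound 1 `Cc1nc2c(OCc3ccccc3)cccn2c1C(N)=O` gives 42% in a functional assay on the whole organism with Rattus norvegicus as the target, with a stated time of 4 h, at a dose of 40 mg/kg by the intraperitoneal route; a lower number here means less inhibition, a higher number more inhibition at the dose given (going by the name of the read-out). Compound 2 `CCSCc1c(C)nc2c(OCc3ccccc3)cccn12` gives 36% in this assay; the step of a number 6 percentage points lower from compound 1 to compound 2 (within the scatter) is within the scatter, so compound 2 stands level with compound 1 on the two numbers available. Compound 3 `Cc1nc2c(OCc3ccccc3)cccn2c1CC1=NCCN1` differs from compound 2 by a group of 5 heavy atoms (3 carbon, 2 nitrogen; one five-membered non-aromatic ring with 2 hetero atoms) in place of a group of 3 heavy atoms (2 carbon, 1 sulfur; no ring), on a saturated chain carbon bound to an aromatic carbon. Among the compounds with values here, only one measured step exists, and it concerns a different exchange, the replacement of carbamoyl by (ethylsulfanyl)methyl, which moved the read-out by a number 6 percentage points lower from compound 1 to compound 2 (within the scatter), a size within the scatter. Within the data shown here, no measured pair informs the exchange of ethylsulfanyl for the entering ring, so the expectation rests on the two measured compounds alone. Compound 3 is therefore estimated at 38%, with a range from 18% to 60%. The step of a number 2 percentage points higher from compound 2 to compound 3 (within the scatter) is expected to stay within the scatter, in no clear direction.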

Compound 3, a percentage reported as inhibition, in the whole organism at one dose (the size of the read-out at that dose, not a potency): 69%
Estimate against measurement, compound 3: 31 percentage points below; the whole stated range lies below it.
By their numbers in this assay, from the lowest: compounds 2 and 1 (each within the scatter of the next); then compound 3.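

The place on a saturated chain carbon bound to an aromatic carbon proves far from indifferent in this assay, since the ring entering for ethylsulfanyl gives a number 33 percentage points higher from compound 2 to compound 3 (beyond the scatter) and so a change that the earlier step, within the scatter, gave no sign of. The same ring on its carbon link also stands apart from the carbamoyl group on the aromatic carbon, with a number 27 percentage points higher from compound 1 to compound 3 (beyond the scatter) as the printed step, which leaves compound 3 clear of both other compounds. Nothing available here accounts for this rise.

From the compounds shown here alone, whether the gain needs the whole ring or only its nitrogen atoms stays open, and a dimethylamino group or a cyclopentyl ring on that same carbon would begin to separate the two. With a single dose and a single time shown, how the inhibition changes with dose also remains unknown.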